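Moving and Lengthening a Basic Side Chain on a Sulfonamide

The compounds below may be only part of what the source reports. "The series", "measured", "known", "first", "only" and "open" are said of these compounds alone.

Measured compounds:
- compound 1 `CCCCCCNC(=O)Nc1ccc(S(=O)(=O)Nc2ccccc2)cc1` — 4300 nM
- compound 2 `CCCCCCNC(=O)Nc1ccc(S(=O)(=O)Nc2ccc(CN)cc2)cc1` — 1720 nM

In an assay on isolated protein for inhibition of growth hormone secretagogue receptor type 1 (Homo sapiens) (on this read-out lower numbers stand for stronger inhibition and higher numbers for weaker inhibition), compound 1 gives 4300 nM, while compound 2 gives 1720 nM. Among the compounds with values here, the only step between measured compounds runs a 2.5-fold lower number from compound 1 to compound 2 (0.40 log units; beyond the scatter), so compound 2 stands at the lower of the two numbers, with compound 1 as its nearest neighbour.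

Compound 3 `CCCCCCNC(=O)Nc1ccc(S(=O)(=O)Nc2cccc(CCCN)c2)cc1` has not yet been measured. It differs from compound 2 by 3-(3-aminopropyl)phenyl in place of 4-(aminomethyl)phenyl on a sulfonamide nitrogen. This is two changes at once: the basic chain grows from one carbon to three, and it moves to another carbon of the same ring.

The step from compound 1 to compound 2 shows that adding the aminomethyl group helps modestly, but nothing measured here tells how a longer chain or a different ring carbon would behave. Within the data shown here, the single related step is small, so the expectation is a number close to that of compound 2, with no step beyond the scatter: compound 3 is estimated at 1500 nM, the step of a 1.1-fold lower number from compound 2 to compound 3 (0.06 log units; within the scatter) being expected to stay inside the usual spread, with a range from 500 nM to 4500 nM.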

Compound 3, half-maximal inhibitory concentration: 429 nM
Beside the measured number, compound 3's estimate is 3.5-fold (0.54 log units) above it; measured number outside the range, below it.
By their numbers in this assay, from the lowest: compound 3; then compound 2; then compound 1.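

In this assay, the step of a 4.0-fold lower number from compound 2 to compound 3 (0.60 log units; beyond the scatter) shows that this sulfonamide nitrogen substituent can still shift the number beyond the scatter, which compound 2 alone could not show, though 3-(3-aminopropyl)phenyl differs from 4-(aminomethyl)phenyl in both chain length and ring carbon, so the gain cannot be credited to either change alone. Measured against the unsubstituted phenyl of compound 1, the step of a 10-fold lower number from compound 1 to compound 3 (1.00 log units; beyond the scatter) is larger than the step of a 2.5-fold lower number from compound 1 to compound 2 (0.40 log units; beyond the scatter), so among these three compounds the 3-aminopropyl group gives the greater gain over hydrogen. No supporting measurement is available to explain why the number falls.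

The compounds shown leave open how much of the gain comes from the longer chain and how much from the ring carbon it occupies; an aminomethyl group on the ring carbon used in compound 3, or a 3-aminopropyl group on the ring carbon used in compound 2, would separate the two. They also leave open whether a longer chain, such as 4-aminobutyl, would lower the number further, and whether the amine itself matters, which a hydroxyl or a carboxylic acid at the end of the chain could test.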